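The compounds below may be only part of what the source reports. "The series", "measured", "known", "first", "only" and "open" are said of these compounds alone.

In a functional assay on HeLa cells (Homo sapiens) for inhibition, read by MTT assay, with a stated time of 72 h (on this read-out higher numbers stand for weaker inhibition and lower numbers for stronger inhibition), compound 1 (`O=[N+]([O-])c1ccc(-c2nnc(SCCCN3CCN(c4nc5ccccc5o4)CC3)o2)cc1`) gives 114000 nM, compound 2 (`O=C(NCc1nnc(SCCCN2CCN(c3nc4ccccc4o3)CC2)o1)c1ccccc1`) gives 63900 nM and compound 3 (`O=[N+]([O-])c1ccc(-c2nnc(SCCCN3CCN(c4nc5ccccc5s4)CC3)o2)cc1`) gives 97800 nM. These three numbers lie within the usual scatter of one another, so compound 3 cannot be separated from the other two.

Compound 4 (`CC(C)(C)Oc1ccc(-c2nnc(SCCCN3CCN(c4nc5ccccc5s4)CC3)o2)cc1`) differs from compound 3 in one group: tert-butoxy in place of nitro on an aromatic carbon. In words, this is tert-butoxy in place of nitro on an aromatic carbon. Going by the values given here, no measured pair makes this exact swap, so the evidence is indirect. Putting benzamidomethyl in place of 4-nitrophenyl gave a 1.8-fold lower number from compound 1 to compound 2 (0.25 log units; within the scatter). That change touches the same part of the molecule. Putting 1,3-benzothiazol-2-yl in place of 1,3-benzoxazol-2-yl, a change elsewhere, gave a 1.2-fold lower number from compound 1 to compound 3 (0.07 log units; within the scatter). Both steps stay within the scatter, so no step beyond the scatter is expected in this assay, in either direction. The estimated change is a 1.2-fold lower number from compound 3 to compound 4 (0.09 log units; within the scatter). The value expected for compound 4 is 80000 nM, with an estimated range of 25000 nM to 200000 nM.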

Compound 4, half-maximal inhibitory concentration: 217000 nM
For compound 4 the middle estimate is 2.7-fold (0.43 log units) below the measured one, and the stated range ends below it.
By their numbers in this assay, from the lowest: compounds 2, 3, 1 and 4 (each within the scatter of the next, the first and the last beyond it).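

Going by these compounds alone, putting tert-butoxy in place of nitro, on the aromatic carbon para to a large group, gives the first step in this assay that lies beyond the scatter: a 2.2-fold higher number from compound 3 to compound 4 (0.35 log units; beyond the scatter). Within the data shown here, the step is modest, but it shows that this position of the ring can register a change of group, and here the change runs towards weaker inhibition, something the earlier steps could not show. No measurement bearing on this result is available, so the step stands as an observation without an explanation.

From the compounds shown here alone, it remains open how a methoxy group, an amine or a carboxylic acid would read at this same position. Also open, going by these compounds, is whether tert-butoxy would shift the number in the same direction with 1,3-benzoxazol-2-yl on the ring nitrogen, as in compound 1.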